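Trimming the ring substituent on the aromatic nitrogen

The compounds below may be only part of what the source reports. "The series", "measured", "known", "first", "only" and "open" are said of these compounds alone.

Of the compounds shown here, three sharing one core have been measured in an assay on HEK293 cells for inhibition of Leucine-rich repeat serine/threonine-protein kinase 2 variant G2019S (Homo sapiens), with a stated time of 48 h; a lower number here means a stronger inhibitor, a higher number a weaker inhibitor. Compound 1 `Cc1c(Nc2nc(N)c3c(C#N)c(N4CCC[C@H]4C)n(C)c3n2)cnn1[C@H]1CCOC1` gives 51 nM. Compound 2 `Cc1c(Nc2nc(N)c3c(C#N)c(N4CCC[C@H]4C)n(C)c3n2)cnn1CC1(O)COC1` gives 120 nM, and compound 3 `Cc1nn(CC(C)(C)O)cc1Nc1nc(N)c2c(C#N)c(N3CCC[C@H]3C)n(C)c2n1` gives 180 nM. Compound 2 therefore stands second highest of the three numbers: its gap to compound 3 is within the scatter, whereas a 2.4-fold higher number from compound 1 to compound 2 (0.37 log units; beyond the scatter) lies beyond it.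

The unmeasured compound 4 `Cc1c(Nc2nc(N)c3c(C#N)c(N4CCC[C@H]4C)n(C)c3n2)cnn1C1COC1` differs from compound 2 in one place: oxetan-3-yl in place of (3-hydroxyoxetan-3-yl)methyl on an aromatic nitrogen. The change sits on an aromatic nitrogen of a five-membered aromatic ring with 2 nitrogen, next to the ring nitrogen and next to the ring atom that bears a methyl group.

Within the data shown here, the only measured step that bears on this is a 2.4-fold higher number from compound 1 to compound 2 (0.37 log units; beyond the scatter), in which a ring bound to the aromatic nitrogen gave way to a methylene-linked ring carrying a hydroxyl. Compound 4 returns to a ring bound to that nitrogen, now four-membered and without the hydroxyl, so a modest move back toward a lower number is expected, though a result within the scatter cannot be ruled out. Compound 4 is accordingly estimated at 70 nM, with a range from 30 nM to 170 nM. This corresponds to an expected 1.7-fold lower number from compound 2 to compound 4 (0.23 log units; within the scatter).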

Compound 4, half-maximal inhibitory concentration: 190 nM
Compound 4: the middle estimate sits 2.7-fold (0.43 log units) below what was measured; the measured number lies above the stated range.
By their numbers in this assay, from the lowest: compound 1; then compounds 2, 3 and 4 (each within the scatter of the next).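

In this assay, replacing (3-hydroxyoxetan-3-yl)methyl with oxetan-3-yl on the aromatic nitrogen gives a 1.6-fold higher number from compound 2 to compound 4 (0.20 log units; within the scatter), so the two substituents cannot be told apart here, although the change goes from 6 heavy atoms and 1 hydrogen-bond donor to 4 heavy atoms and 0 hydrogen-bond donors. A ring bound directly to this nitrogen therefore does not by itself bring the number back toward that of compound 1: exchanging oxolan-3-yl for oxetan-3-yl gives a 3.7-fold higher number from compound 1 to compound 4 (0.57 log units; beyond the scatter), even though both rings are attached directly. Among compounds 1, 2 and 4, oxolan-3-yl alone stands apart, and nothing shown here accounts for that difference between the rings.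

The compounds shown leave open whether the lower number of compound 1 depends on the ring oxygen or on the carbon framework of the five-membered ring, a question that a cyclopentyl group on the same nitrogen would address. They also leave open how a six-membered oxan-4-yl ring at this position would compare with oxolan-3-yl.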